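This account rests on a few compounds, and the source may have more. Where it says the series, first, only, none or still open, it means among the compounds named here.

Among the compounds with values here, compound 3, with the structure `COc1ccc(C(=O)CSc2nnc(-c3cc(OC)c(OC)c(OC)c3)n2N2C(=O)c3ccccc3C2=O)cc1`, is the only compound here to give an actual number in a functional assay on HepG2 cells (Homo sapiens) for cytotoxicity, read by MTT assay, with a stated time of 48 h; on this read-out lower numbers stand for stronger inhibition and higher numbers for weaker inhibition: compound 3 gives 28700 nM. The two companions sit at a limit of this assay rather than at a number. Compound 1, with the structure `COc1cc(-c2nnc(SCc3ccccc3Cl)n2N2C(=O)c3ccccc3C2=O)cc(OC)c1OC`, gives only the limit > 200000 nM. Compound 2, with the structure `COc1cc(-c2nnc(SC)n2N2C(=O)c3ccccc3C2=O)cc(OC)c1OC`, likewise gives only the limit > 200000 nM. Between those two the step is unreadable: a step that the two limits leave unreadable from compound 1 to compound 2. Toward compound 3 the picture is clearer, since there is an at least 6.9-fold lower number from compound 1 to compound 3 (0.84 log units; beyond the scatter) and also an at least 6.9-fold lower number from compound 2 to compound 3 (0.84 log units; beyond the scatter); both point the same way and lie beyond the scatter, and in both cases what enters on the saturated chain carbon bound to sulfur is the (4-methoxyphenyl)carbonyl group. The evidence is the limit of > 200000 nM in this assay, at which 2 of the 3 values shown sit.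

Compound 4, with the structure `COc1cc(-c2nnc(SCC(=O)c3ccccc3C)n2N2C(=O)c3ccccc3C2=O)cc(OC)c1OC`, keeps that carbonyl-bearing chain and alters only the aromatic ring at its end: 2-methylphenyl in place of 4-methoxyphenyl on a carbonyl carbon. Within the data shown here, none of the measured steps varies this ring; they concern whether the carbonyl-bearing group is present at all. The expectation for this assay is therefore no step beyond the scatter, so the step from compound 3 to compound 4 is estimated as a 1.0-fold higher number from compound 3 to compound 4 (0.02 log units; within the scatter). Compound 4 is expected to give about 30000 nM, within a range from 10000 nM to 90000 nM.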

Compound 4, half-maximal inhibitory concentration: > 200000 nM
Compound 4: no number, only a limit; the forecaster's own chance of this, stated with the estimate: 15%; middle value at least 6.6-fold (0.82 log units) from the limit.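

Until now, the measured steps concerned only whether a carbonyl-bearing group was present on the saturated chain carbon bound to sulfur; this result shows that the aromatic ring at the end of that group also counts in this assay, with an at least 6.9-fold higher number from compound 3 to compound 4 (0.84 log units; beyond the scatter). The carbonyl-bearing chain alone therefore does not secure a measurable number here, and 4-methoxyphenyl and 2-methylphenyl cannot be treated as interchangeable on this carbonyl carbon among these compounds. The steps from compound 1 and from compound 2 to compound 4 cannot be read, as both ends of each are limits, and most of the picture rests on such limits: the limit of > 200000 nM in this assay, at which 3 of the 4 values shown sit.

This change removes a methoxy group and brings in a methyl group while also altering the place of the substituent on the ring, so the compounds shown cannot say which of these matters. A 4-methylphenyl or a 2-methoxyphenyl group on the same carbonyl carbon would separate the two, while a 4-aminophenyl group would test whether a different substituent at that ring position can give a measurable number.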